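The source may hold more compounds than are shown below. What is called first, only, known or untested is meant among the compounds shown, and "the series" means these compounds.

Compound 1, with the structure `Cc1cc(N)cc(C)c1Oc1cc(Nc2ccc(C#N)cc2)c(N)cc1C(F)(F)F`, was tested in an ADME assay on TZM cells (Homo sapiens) for cytotoxicity, read by XTT assay, with a stated time of 4 days (a higher number here means that more compound is tolerated, a lower number that less compound is tolerated), where compound 1 gives 15800 nM. Compound 3, with the structure `Cc1cc(/C=C/C#N)cc(C)c1Oc1cc(Nc2ccc(C#N)cc2)c(N)cc1C(=O)O`, gives 14900 nM in this assay; compound 1 and compound 3 thus sit within the usual scatter of each other, and no order between them can be read. Compound 2, with the structure `COC(=O)c1cc(N)c(Nc2ccc(C#N)cc2)cc1Oc1c(C)cc(/C=C/C#N)cc1C`, reaches only a limit of the assay, > 22800 nM, not a number. Among the compounds with values here, the one measured step, an at least 1.5-fold lower number from compound 2 to compound 3 (0.18 log units; that floor lies within the scatter), rests on that limit of > 22800 nM in this assay, at which 1 of the 3 values shown sits, and therefore shows no sure change.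

Compound 4 has the structure `CC(=O)/C=C/c1cc(C)c(Oc2cc(Nc3ccc(C#N)cc3)c(N)cc2C(F)(F)F)c(C)c1` and differs from compound 1 by 2-acetylethenyl in place of amino on an aromatic carbon. Within the data shown here, none of the measured steps covers this kind of change, so the only guide is that the two numbers in hand, from compound 1 and compound 3, lie close together. Compound 4 is therefore expected to give 15000 nM, with a range from 6000 nM to 30000 nM. The expected step is a 1.1-fold lower number from compound 1 to compound 4 (0.02 log units; within the scatter), that is, nothing beyond the scatter.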

Compound 4, half-maximal cytotoxic concentration: > 8600 nM
Compound 4: no number, only a limit; the forecaster's own chance of this, stated with the estimate: 25%; the middle value does not contradict the limit.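

In this assay compound 4 gives only a limit of the assay, > 8600 nM, not a number. The step from compound 1 to compound 4 therefore cannot be read. The compounds shown leave open whether 2-acetylethenyl in place of amino changes how much compound is tolerated.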